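Dropping the Chloro Group from Compound 3

A few compounds are considered here, and "the series" means these few. Any claim that something is new, unique, unknown or untested is made for them only; others in the source may bear on it.

Compound 1 `CNC(=O)c1ccc(Sc2cccc(NC(=S)Nc3ccc(F)c(Cl)c3)c2)nc1` reaches only a limit in a functional assay on B16-BL6 cells (Mus musculus) for cytotoxicity, read by MTT assay, with a stated time of 48 h (a higher number here means a weaker inhibitor, a lower number a stronger inhibitor), giving > 100000 nM. Compound 2 `CNC(=O)c1ccc(Sc2cccc(NC(=S)Nc3ccc(F)c(F)c3)c2)nc1` gives 58200 nM in this assay, a change of an at least 1.7-fold lower number from compound 1 to compound 2 (0.23 log units; that floor lies within the scatter). Compound 3 `CNC(=O)c1ccc(Sc2cccc(NC(=S)Nc3ccc(Cl)c(C(F)(F)F)c3)c2)nc1` gives 19800 nM in this assay, the lowest of the two numbers shown, with compound 2 the nearest at a higher number beyond the scatter. Compound 4 `CNC(=O)c1ccc(Sc2cccc(NC(=S)Nc3cccc(C(F)(F)F)c3)c2)nc1` differs from compound 3 by hydrogen in place of chloro on an aromatic carbon. No measured step removes a chloro group outright; the single step shown, an at least 1.7-fold lower number from compound 1 to compound 2 (0.23 log units; that floor lies within the scatter), swaps one halogen for another and stays within the scatter. The expectation for compound 4 is therefore a moderately higher number, a step of a 2.5-fold higher number from compound 3 to compound 4 (0.40 log units; beyond the scatter). Compound 4 is estimated at 50000 nM, within 15000 nM to 150000 nM.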

Compound 4, half-maximal inhibitory concentration: 19200 nM
For compound 4 the middle estimate is 2.6-fold (0.42 log units) above the measured one; the range from low to high includes it.
By their numbers in this assay, from the lowest: compounds 4 and 3 (each within the scatter of the next); then compound 2. At a limit, above all of these: compound 1.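

In this assay, hydrogen in place of chloro, ortho to a trifluoromethyl group, leaves the two compounds indistinguishable: a 1.0-fold lower number from compound 3 to compound 4 (0.01 log units; within the scatter). The chloro group is therefore not needed at this position for this read-out, while the 3-(trifluoromethyl)phenyl group does separate from the two other rings on the amide-type nitrogen, with a 3.0-fold lower number from compound 2 to compound 4 (0.48 log units; beyond the scatter) and an at least 5.2-fold lower number from compound 1 to compound 4 (0.71 log units; beyond the scatter). The last of these steps is only a floor, because compound 1 stands at a limit: the limit of > 100000 nM in this assay, at which 1 of the 4 values shown sits. Going by these compounds, whether an amine or a methoxy group at this position would shift the number remains open, as does how far the trifluoromethyl group itself matters.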